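The compounds below may be only part of what the source reports. "The series", "measured", "known", "first", "only" and "open" are said of these compounds alone.

Of the compounds shown here, three that share one core have been measured in a functional assay (muscle tissue) with Cavia porcellus as the target; a lower number here means that less compound is needed, a higher number that more compound is needed for the effect. Compound 1 `COC(=O)C1=C(C)NC(C)=C(C(=O)OC)C1c1ccccc1` gives 28.2 nM in this assay. Compound 2 `COC(=O)C1=C(C)N=C(C)/C(=C(\O)OC)C1c1ccccc1C#N` gives 15.9 nM, the lowest of the three numbers, although its gap to compound 1 lies within the scatter, so those two cannot be ranked against each other. Compound 3 `COC(=O)C1=C(C)N=C(C)/C(=C(\O)OC)C1c1cc([N+](=O)[O-])ccc1O` gives 100 nM, a number that sits beyond the scatter above compound 2. A fourth compound, compound 4 `COC(=O)C1=C(C)N=C(C)/C(=C(\O)OC)C1c1cccc(F)c1`, has not yet been measured. It differs from compound 2 in one place: 3-fluorophenyl in place of 2-cyanophenyl on a saturated ring carbon. Within the data shown here, no measured pair in this set isolates a swap of one aryl group for another, and the aryl variations among compounds 1, 2 and 3 move the numbers only by the gaps just stated. The expected step is therefore small and likely within the scatter: a 1.6-fold higher number from compound 2 to compound 4 (0.20 log units; within the scatter). Compound 4 is estimated to give about 25 nM in this assay, with a range from 8 nM to 80 nM.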

Compound 4, half-maximal effective concentration: 20.9 nM
Estimate against measurement, compound 4: 1.2-fold (0.08 log units) above; the range from low to high includes it.
By their numbers in this assay, from the lowest: compounds 2, 4 and 1 (each within the scatter of the next); then compound 3.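

Among these compounds, the swap of 2-cyanophenyl for 3-fluorophenyl on this saturated ring carbon gives a 1.3-fold higher number from compound 2 to compound 4 (0.12 log units; within the scatter) in this assay, and it is the first comparison here that changes one place only. The group that leaves carries a triple bond and a hydrogen-bond acceptor, the group that enters carries neither, and in this pair the numbers still cannot be told apart. Nothing at hand explains why they stay so close.

This single step says nothing about groups of another kind on the same carbon, such as an aminophenyl group, a carboxylic acid or a longer chain. As far as these compounds go, what an ethyl group in place of a ring methyl group would do, or a longer ester in place of a methoxycarbonyl group, also stays open.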